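From 1H-pyrazol-4-yl to 1-methyl-1H-pyrazol-4-yl

The compounds below may be only part of what the source reports. "The series", "measured", "known", "first", "only" and "open" are said of these compounds alone.

- compound 1 `CC/C(=C(/c1ccc(/C=C/C(=O)O)cc1)c1ccc(-c2cscn2)cc1)c1ccccc1`: 120 nM
- compound 2 `CC/C(=C(/c1ccc(/C=C/C(=O)O)cc1)c1ccc(-c2cnsc2)cc1)c1ccccc1`: 120 nM
- compound 3 `CC/C(=C(/c1ccc(/C=C/C(=O)O)cc1)c1ccc(-c2cn[nH]c2)cc1)c1ccccc1`: 40 nM

In a functional assay on MCF7 cells (Homo sapiens) for antiproliferative activity, read by CellTiter-Glo, with a stated time of 5 days (a lower number here means a stronger inhibitor, a higher number a weaker inhibitor), compound 3 holds the lowest of the three numbers at 40 nM, beyond the scatter of both others. Compound 4 `CC/C(=C(/c1ccc(/C=C/C(=O)O)cc1)c1ccc(-c2cnn(C)c2)cc1)c1ccccc1` differs from it by one change: methyl in place of hydrogen on an aromatic nitrogen. Among the measured compounds shown here, no measured step places methyl on a ring nitrogen. The closest evidence is ring replacement at the same attachment: a 3.0-fold lower number from compound 1 to compound 3 (0.48 log units; beyond the scatter) and a 3.0-fold lower number from compound 2 to compound 3 (0.48 log units; beyond the scatter), both modest, and no change at the digits printed from compound 1 to compound 2 (within the scatter). These steps offer only indirect guidance, so a small rise in this assay is expected, probably within the scatter. For compound 4 the estimate is 70 nM, with an expected range of 25 nM to 180 nM. The expected step is a 1.8-fold higher number from compound 3 to compound 4 (0.24 log units; within the scatter).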

Compound 4, half-maximal inhibitory concentration: 80 nM
Beside the measured number, compound 4's estimate is 1.1-fold (0.06 log units) below it; the measured number falls inside the stated range.
By their numbers in this assay, from the lowest: compounds 3, 4, 1 and 2 (each within the scatter of the next, the first and the last beyond it).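

In this assay, methyl on the aromatic nitrogen of the 1H-pyrazol-4-yl group gives a 2.0-fold higher number from compound 3 to compound 4 (0.30 log units; within the scatter) and so leaves no readable change at this position. The 1-methyl-1H-pyrazol-4-yl group also stays close to both thiazoles, with a 1.5-fold lower number from compound 1 to compound 4 (0.18 log units; within the scatter) and a 1.5-fold lower number from compound 2 to compound 4 (0.18 log units; within the scatter) at the same attachment, whereas compound 3 stood apart from them. Nothing available here accounts for these numbers.

Open, as far as these compounds go, is how this nitrogen responds to a group larger than methyl, such as an ethyl, a longer chain or one ending in an amine.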